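Removing the benzyl group from a non-toxic coumarin amide

The source may hold more compounds than are shown below. What is called first, only, known or untested is meant among the compounds shown, and "the series" means these compounds.

In an ADME assay on A549 cells (Homo sapiens) for cytotoxicity, read by CellTiter-Glo (a lower number here means that less compound is tolerated, a higher number that more compound is tolerated), compound 2 `NC(=O)C1CCN(CC(O)COc2ccc3c(C4CC4)c(Cc4ccccc4)c(=O)oc3c2)CC1` reports only the assay limit, > 100000 nM. Compound 1 `Cc1cc(=O)oc2cc(OCC(O)CN3CCC(C(N)=O)CC3)ccc12` likewise reaches only the limit of this assay, > 100000 nM. Compound 3 `NC(=O)C1CCN(CC(O)COc2ccc3c(-c4ccccc4)c(Cc4ccccc4)c(=O)oc3c2)CC1` gives a number in this assay, 25200 nM. Going by the values given here, the one measured step, an at least 3.9-fold lower number from compound 2 to compound 3 (0.59 log units; beyond the scatter), concerns the cyclopropyl position, not the benzyl, so no measured step bears directly on compound 4 `NC(=O)C1CCN(CC(O)COc2ccc3c(C4CC4)cc(=O)oc3c2)CC1`, which differs from compound 2 by hydrogen in place of benzyl on an aromatic carbon. With the limit of > 100000 nM in this assay, at which 2 of the 3 values shown sit, the shared core without a phenyl on the cyclopropyl position has so far stayed at the limit. The step from compound 2 to compound 4 is therefore expected to be none beyond the scatter, a step that the limit leaves unreadable from compound 2 to compound 4. Compound 4 is estimated at 150000 nM, between 60000 nM and 500000 nM.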

Compound 4, half-maximal cytotoxic concentration: > 100000 nM
Compound 4: no number, only a limit; the forecaster's own chance of this, stated with the estimate: 80%; the middle value does not contradict the limit.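

The steps from compound 1 and from compound 2 to compound 4 cannot be read, since all three compounds give only a limit: the limit of > 100000 nM in this assay, at which 3 of the 4 values shown sit.

The compounds shown leave open whether hydrogen in place of benzyl, or cyclopropyl in place of methyl, changes the tolerated concentration at all.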